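The source may report more compounds than this note shows. Statements on the series, on what has been measured and on what is new or still open speak of the compounds shown alone.

Going by the values given here, compound 3 `COc1cc(CCc2ccccc2F)cc(OC)c1O` is the one compound here with a measured number: in a functional assay on MDA-MB-231 cells (Homo sapiens) for antiproliferative activity, read by MTT assay, with a stated time of 72 h (a lower number here means a stronger inhibitor, a higher number a weaker inhibitor), compound 3 gives 9220 nM. Compound 1 `COc1cc(CCc2ccc(F)cc2)cc(OC)c1O` reaches only a limit of the assay, giving > 25000 nM. Compound 2 `COc1cc(CCc2cccc(F)c2)cc(OC)c1O` likewise stops at a limit, giving > 25000 nM. That two of the three results sit at a limit is itself a piece of evidence (the limit of > 25000 nM in this assay, at which 2 of the 3 values shown sit). Compound 4 `COc1ccccc1CCc1cc(OC)c(O)c(OC)c1` has not been measured. It differs from compound 3 in one place: methoxy in place of fluoro on an aromatic carbon. Among the compounds with values here, no measured pair shows what such a swap does, so the expected step is uncertain. The step is estimated to be a 1.6-fold higher number from compound 3 to compound 4 (0.21 log units; within the scatter). A limit would not surprise. Compound 4 is therefore expected to give about 15000 nM, within a range from 4000 nM to 50000 nM.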

Compound 4, half-maximal inhibitory concentration: > 25000 nM
Compound 4 was reported as a limit; the forecaster's own chance of this, stated with the estimate: 40%; middle value at least 1.6-fold (0.22 log units) from the limit.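

In this assay, putting methoxy in place of fluoro on an aromatic carbon ortho to a large group weakens the result, giving an at least 2.7-fold higher number from compound 3 to compound 4 (0.43 log units; beyond the scatter). That size is only a lower bound, as compound 4 gives a limit and not a number. Compound 3 therefore stays the only compound with a measured number, and the limit now holds most of the set: the limit of > 25000 nM in this assay, at which 3 of the 4 values shown sit.

On these data alone, how much weaker compound 4 truly is remains open. So does whether chloro, hydroxy or an amine on this carbon would keep a measurable number.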